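One Methyl Added: From Compound 1 to Compound 3

The source may hold more compounds than are shown below. What is called first, only, known or untested is meant among the compounds shown, and "the series" means these compounds.

In an ADME assay on HEK293 cells (Homo sapiens) for cytotoxicity, read by resazurin assay, with a stated time of 24 h (a higher number here means that more compound is tolerated, a lower number that less compound is tolerated), compound 1 `O=C(O)c1c(O)cccc1CCc1ccc2ccccc2c1` gives > 100000 nM as a limit of the assay and not as a number. In this assay compound 2 `COc1cc(C=Cc2ccc3ccccc3c2)c(C(=O)O)c(OC)c1` also gives > 100000 nM as a limit and not as a number. Compound 1 therefore stands at the limit of > 100000 nM in this assay, at which 2 of the 2 values shown sit, and has no exact value.

Compound 3 `Cc1cc(O)c(C(=O)O)c(CCc2ccc3ccccc3c2)c1` differs from compound 1 by one change methyl in place of hydrogen on an aromatic carbon with methyl in place of hydrogen on an aromatic carbon, para to a carboxy group. Among the compounds with values here, no pair of measured compounds shows what such a change does. The expectation therefore rests on compound 1 and its limit of > 100000 nM and on the small size of the change. The step that the limit leaves unreadable from compound 1 to compound 3 is expected to stay within the usual scatter, in neither direction. In this assay the estimated value for compound 3 is 120000 nM with 50000 nM and 300000 nM as the expected ends of the range.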

Compound 3, half-maximal cytotoxic concentration: 40000 nM
Compound 3: the middle estimate sits 3.0-fold (0.48 log units) above what was measured; measured number below the stated range.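

Methyl in place of hydrogen at this position, para to a carboxy group, is not a silent change in this assay: the result is an at least 2.5-fold lower number from compound 1 to compound 3 (0.39 log units; beyond the scatter). Within the data shown here, one added carbon on the aromatic ring is thus enough to bring the core of compound 1 down to a value that can be read as a number, and compound 3 is the first compound here to give one. Compound 1 has a limit and not a number, so the true step may be larger than the one printed: the limit of > 100000 nM in this assay, at which 2 of the 3 values shown sit.

On these data alone, what an ethyl chain, a chlorine or an amine would do at this same position stays open, and so does whether the step is tied to methyl alone. Also open, as far as these compounds go, is whether methyl here would act the same way on a core carrying other groups, such as that of compound 2.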